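The compounds below may be only part of what the source reports. "The series", "measured", "known", "first", "only" and "open" are said of these compounds alone.

Measured so far:
compound 1, `CC(/C=N/Nc1ccc([N+](=O)[O-])cc1)=N\NC(=O)c1ccccc1C` — 6000 nM
compound 2, `CC(/C=N/Nc1ccc([N+](=O)[O-])cc1)=N\NC(=O)c1ccccc1F` — > 12000 nM
compound 3, `CC(/C=N/Nc1ccc([N+](=O)[O-])cc1)=N\NC(=O)c1ccc(N)cc1` — > 12000 nM

In a functional assay on cells (Splenocyte, Mus musculus, strain BALB/c) for inhibition, read by scintillation counting and thymidine incorporation, with a stated time of 72 h (on this read-out higher numbers stand for weaker inhibition and lower numbers for stronger inhibition), compound 1 gives 6000 nM. For compound 2 the assay reports only a limit, > 12000 nM. For compound 3 likewise only a limit is given, > 12000 nM, so compound 3 stands at the limit of > 12000 nM in this assay, at which 2 of the 3 values shown sit, with no number of its own.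

Compound 4, `CC(/C=N/Nc1ccc([N+](=O)[O-])cc1)=N\NC(=O)c1ccccc1Cl`, is not yet measured. It differs from compound 3 in one place: 2-chlorophenyl in place of 4-aminophenyl on a carbonyl carbon. The step from compound 1 to compound 3 bears on this change in the reverse direction, an at least 2.0-fold higher number from compound 1 to compound 3 (0.30 log units; that floor lies within the scatter), while the step from compound 2 to compound 3 is a step that the two limits leave unreadable from compound 2 to compound 3. Among the compounds with a group on the carbonyl carbon bearing a substituent on the phenyl, only compound 1 returned a number. Because compound 3 sits at a limit, the size of the step to compound 4 in this assay cannot be read from the data; a lower number than the limit is expected. Compound 4 is therefore estimated at 7000 nM, within 3000 nM to 20000 nM, which is an expected step of an at least 1.7-fold lower number from compound 3 to compound 4 (0.23 log units; that floor lies within the scatter).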

Compound 4, half-maximal inhibitory concentration: > 12000 nM
Compound 4 ended at the assay's limit; the forecaster's own chance of this, stated with the estimate: 40%; middle value at least 1.7-fold (0.23 log units) away from the limit.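

In this assay compound 4 gives only a limit, > 12000 nM, so a 2-chlorophenyl on the carbonyl carbon yields no number of its own. Among the compounds shown here, with this result, the limit now covers most of the series, and compound 1 remains the only compound with a number: the limit of > 12000 nM in this assay, at which 3 of the 4 values shown sit. Chloro in place of methyl gives an at least 2.0-fold higher number from compound 1 to compound 4 (0.30 log units; that floor lies within the scatter), so this change cannot be said to exceed ordinary scatter, and the steps to compound 4 from compound 2 and compound 3 cannot be read, as both ends are limits.

As far as these compounds go, it remains open how far compound 2, compound 3 and compound 4 lie past the limit, and so whether the methyl of compound 1 truly sets it apart. How an ethyl or a methoxy group in place of that methyl would read is also unknown.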